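Working notes: compound 2 to compound 3 in cytotoxicity

The source may report more compounds than this note shows. Statements on the series, on what has been measured and on what is new or still open speak of the compounds shown alone.

Measured compounds:
compound 1 `CN(C)c1ccc(/C=C2\S/C(=N\c3csc(-c4ccc(Cl)cc4)c3)NC2=O)cc1` — a functional assay on HCT-116 cells (Homo sapiens) for cytotoxicity, read by MTT assay, with a stated time of 72 h; a lower number here means a stronger inhibitor, a higher number a weaker inhibitor: 500 nM
compound 2 `CCCCCC/C=C1\S/C(=N\c2csc(-c3ccc(Cl)cc3)c2)NC1=O` — this assay : "not determined" (no result reported)

Going by the values given here, compound 2 stands without a number in this assay, its entry being "not determined" (no result reported); the only value in the set belongs to compound 1, which gives 500 nM. Compound 3 `O=C1N/C(=N/c2csc(-c3ccc(Cl)cc3)c2)S/C1=C\c1ccccn1` is the next member. The change from compound 2 is pyridin-2-yl in place of hexyl on a double-bonded chain carbon bound to a double-bonded ring carbon. Among the compounds with values here, no step between measured compounds is available, so the size of this step cannot be read from data, and with compound 2 unmeasured its direction cannot be stated either; whether it lies within or beyond the scatter stays open. The expectation for compound 3 rests only on compound 1 giving 500 nM and on the structural change itself. Compound 3 is expected to give an estimated 1500 nM in this assay, with a range from 300 nM to 8000 nM. A limit instead of a number remains possible for compound 3.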

Compound 3, half-maximal inhibitory concentration: 21600 nM
Compound 3: the middle estimate sits 14-fold (1.16 log units) below what was measured; measured number above the stated range.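

In this assay this position, on a double-bonded chain carbon bound to a double-bonded ring carbon, now has its first readable step: pyridin-2-yl in place of 4-(dimethylamino)phenyl gives a 43-fold higher number from compound 1 to compound 3 (1.64 log units; beyond the scatter) with the rest of the structure unchanged, so the number depends on the group held here. The step from compound 2 to compound 3 cannot be read, as compound 2 has no number, and the hexyl chain therefore cannot be placed relative to either aromatic group. No measurement shown accounts for the size of this step.

Still open, on these data alone, is whether the step follows from losing the dimethylamino group or from the ring nitrogen of pyridin-2-yl. A plain phenyl at this position would separate those two changes, while a measured value for the hexyl compound would show how a chain compares.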